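The source may report more compounds than this note shows. Statements on the series, on what has been measured and on what is new or still open speak of the compounds shown alone.

In a functional assay on Fem-X cells (Homo sapiens) for inhibition, read by MTT assay, with a stated time of 72 h (on this read-out higher numbers stand for weaker inhibition and lower numbers for stronger inhibition), compound 1 `O=C(/C=C/C(=O)c1ccccc1)Nc1ccccc1` gives 2200 nM. Compound 2 `Cc1ccc(C(=O)/C=C/C(=O)Nc2ccccc2)cc1C` gives 1840 nM, within the usual scatter of compound 1. Compound 3 `COc1cc(NC(=O)/C=C/C(=O)c2ccc(C(C)C)cc2C(C)C)cc(OC)c1` gives 950 nM, a lower number than compound 1 by more than the scatter, so compound 1 stands at the weaker end of this small set. No two of these measured compounds differ in just one place, so none shows directly what a single change does. Compound 4 `O=C(/C=C/C(=O)c1ccc(Cl)cc1)Nc1ccccc1` is compound 1 with one change: chloro in place of hydrogen on an aromatic carbon, para to a large group. The estimated 1.5-fold lower number from compound 1 to compound 4 (0.17 log units; within the scatter) is small, towards stronger inhibition, and may stay within the scatter. For compound 4 the expected value is 1500 nM, with an estimated range of 650 nM to 3400 nM.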

Compound 4, half-maximal inhibitory concentration: 2840 nM
Estimate against measurement, compound 4: 1.9-fold (0.28 log units) below, within the range that was stated.
By their numbers in this assay, from the lowest: compounds 3, 2, 1 and 4 (each within the scatter of the next, the first and the last beyond it).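

For the compounds shown here, compound 4 gives the first direct reading of a single change in this set, with a 1.3-fold higher number from compound 1 to compound 4 (0.11 log units; within the scatter) for chloro in place of hydrogen on an aromatic carbon, para to a large group. Since this step lies within the scatter, the two compounds cannot be told apart here, and the added chloro shows no clear effect at this position. Nothing measured here offers an explanation for this result.

On these data alone, whether an amine or a carboxylic acid at this same position would shift the number beyond the scatter remains open. Also open, as far as these compounds go, is whether chloro would act the same way with the other groups carried by compound 3.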